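Removing an Aromatic-Nitrogen Methyl: Expected Half-Life

The source may report more compounds than this note shows. Statements on the series, on what has been measured and on what is new or still open speak of the compounds shown alone.

Compound 1, `COc1cccc(CNC(=O)c2cn(C)c3cc(-c4cn[nH]c4)ccc23)c1`: 0.15 h
Compound 2, `COc1cccc(CNC(=O)c2[nH]c3nc(-c4cn[nH]c4)ccc3c2CN2CCN(C)CC2)c1`: 0.0167 h

Of the compounds shown here, two have been measured in an in vitro ADME assay on microsomes from liver (Homo sapiens) for metabolic stability; a lower number here means that the compound disappears faster, a higher number that the compound lasts longer. Compound 1 gives 0.15 h and stands highest of the two; compound 2 gives 0.0167 h, a gap beyond the scatter. The two structures differ in several places at once, so this pair says nothing about any single change.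

Compound 3, `COc1cccc(CNC(=O)c2c[nH]c3cc(-c4cn[nH]c4)ccc23)c1`, has not yet been measured. It differs from compound 1 in one place: hydrogen in place of methyl on an aromatic nitrogen. Among the measured compounds shown here, no measured pair shows the effect of this change, so the expectation rests on compound 1 alone and on the small size of the change. The expected step is a 1.3-fold higher number from compound 1 to compound 3 (0.12 log units; within the scatter), that is, nothing beyond the scatter. Compound 3 is therefore estimated at 0.2 h, with a range from 0.08 h to 0.5 h.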

Compound 3, half-life: 0.417 h
For compound 3 the middle estimate is 2.1-fold (0.32 log units) below the measured one, and the stated range covers the measured number.
By their numbers in this assay, from the lowest: compound 2; then compound 1; then compound 3.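

Among the compounds shown here, this is the first change in a single place that can be read in this assay: hydrogen in place of methyl on an aromatic nitrogen gives a 2.8-fold higher number from compound 1 to compound 3 (0.44 log units; beyond the scatter), so the compound without the methyl lasts longer. Losing just 1 heavy atom (1 carbon) from the aromatic nitrogen of this five-membered aromatic ring therefore moves the half-life by a step that lies beyond the scatter of repeat measurements. Nothing available here accounts for the rise.

From the compounds shown here alone, this step comes from a single pair on a single core, so it remains open whether the same swap would give a similar step on the core of compound 2. Also open, going by these compounds, is where an ethyl group, a longer chain or a chain ending in an amine on that nitrogen would fall relative to compound 1 and compound 3.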